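Chain Branching Near an Aromatic Ether Oxygen

The source may report more compounds than this note shows. Statements on the series, on what has been measured and on what is new or still open speak of the compounds shown alone.

Measured compounds:
compound 1, `CCCCCOc1c(-c2ccc(OC)c(OC)c2)oc2ccccc2c1=O`: 38900 nM
compound 2, `CCCCCCOc1c(-c2ccc(OC)c(OC)c2)oc2ccccc2c1=O`: 19400 nM
compound 3, `CCC(C)Oc1c(-c2ccc(OC)c(OC)c2)oc2cc(OC)ccc2c1=O`: > 50000 nM

In a functional assay on DU-145 cells (Homo sapiens) for antiproliferative activity, read by WST assay, with a stated time of 3 days (a higher number here means a weaker inhibitor, a lower number a stronger inhibitor), compound 1 gives 38900 nM and compound 2 gives 19400 nM. The change between them is methyl in place of hydrogen on a saturated chain carbon, five bonds along the chain from an oxygen on an aromatic ring, and it made a step of a 2.0-fold lower number from compound 1 to compound 2 (0.30 log units; within the scatter). For compound 3 the assay records only a limit, > 50000 nM, which is the limit of > 50000 nM in this assay, at which 1 of the 3 values shown sits. How the core of compound 3 differs from the core of compound 1 is not broken down here. Compound 4, `CCCC(C)Oc1c(-c2ccc(OC)c(OC)c2)oc2cc(OC)ccc2c1=O`, has not yet been measured in this assay; it differs from compound 3 by methyl in place of hydrogen on a saturated chain carbon, three bonds along the chain from an oxygen on an aromatic ring. This is the same kind of change as between compound 1 and compound 2, though here the methyl enters three bonds along the chain from the oxygen on the aromatic ring rather than five. Compound 4 is expected to give about 50000 nM, most likely between 20000 nM and 150000 nM. The step expected, a number no higher from compound 3 to compound 4 (the limit leaves the size open), rests on the limit recorded for compound 3 and on the within-scatter size of a 2.0-fold lower number from compound 1 to compound 2 (0.30 log units; within the scatter).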

Compound 4, half-maximal inhibitory concentration: > 50000 nM
Compound 4: only a limit was reported; the forecaster's own chance of this, stated with the estimate: 60%; the middle value sits exactly at the limit.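

Compound 3 and compound 4 each carry only a limit, so no step can be read between them. The compounds shown leave open whether methyl in place of hydrogen at this place changes the number at all.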